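Replacing methoxy with hydroxy in a cytotoxicity series

The source may report more compounds than this note shows. Statements on the series, on what has been measured and on what is new or still open speak of the compounds shown alone.

In an ADME assay on NIH3T3 cells (Mus musculus) for cytotoxicity, read by MTT assay, with a stated time of 24 h (on this read-out higher numbers stand for weaker inhibition and lower numbers for stronger inhibition), compound 1 `Oc1cccc(/C=N/n2c(S)nnc2-c2cnccn2)c1` gives 151000 nM, compound 2 `Sc1nnc(-c2cnccn2)n1/N=C/c1ccc(Cl)cc1` gives 218000 nM and compound 3 `COc1ccccc1/C=N/n1c(S)nnc1-c1cnccn1` gives 173000 nM. These three values lie so close together that compound 3 stands within the scatter of both others. Compound 4 `Oc1ccccc1/C=N/n1c(S)nnc1-c1cnccn1` differs from compound 3 by one small change, hydrogen in place of methyl on an oxygen on an aromatic ring. Among the measured compounds shown here, the only measured step, a 1.4-fold higher number from compound 1 to compound 2 (0.16 log units; within the scatter), is a different change, and it stays within the scatter. A shift beyond the scatter is therefore not expected in this assay, and the estimated step is a 1.1-fold lower number from compound 3 to compound 4 (0.03 log units; within the scatter). For compound 4 the expected value is 160000 nM, with an estimated range of 95000 nM to 260000 nM.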

Compound 4, half-maximal inhibitory concentration: 131000 nM
Estimate against measurement, compound 4: 1.2-fold (0.09 log units) above; low and high end bracket the measured number.
By their numbers in this assay, from the lowest: compounds 4, 1, 3 and 2 (each within the scatter of the next).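

Taking hydrogen in place of methyl on this oxygen gives a 1.3-fold lower number from compound 3 to compound 4 (0.12 log units; within the scatter) in this assay, so the switch from methoxy to hydroxy does not separate the two compounds. The 2-hydroxyphenyl group also stays within the scatter of the other aryl groups, with a 1.7-fold lower number from compound 2 to compound 4 (0.22 log units; within the scatter) against 4-chlorophenyl and a 1.2-fold lower number from compound 1 to compound 4 (0.06 log units; within the scatter) against 3-hydroxyphenyl, so none of the four compounds can be told apart here. No evidence bearing on this result is available.

As far as these compounds go, whether a longer chain on this oxygen, or an amine or carboxylic acid in its place, would move the number beyond the scatter remains open.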